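The source may report more compounds than this note shows. Statements on the series, on what has been measured and on what is new or still open speak of the compounds shown alone.

Measured in an in vitro ADME assay on microsomes from liver (Homo sapiens) for metabolic stability; on this read-out higher numbers stand for fast clearance and lower numbers for slow clearance:

compound 1 `Cc1cnc(NC(=O)c2cc(Oc3ccc(S(C)(=O)=O)cc3)c3cn(C)nc3c2)cn1`: < 8 mL/min/kg
compound 2 `Cc1cnc(NC(=O)c2cc(Oc3ccc(S(=O)(=O)C4CC4)cc3)c3cn(C)nc3c2)cn1`: < 8 mL/min/kg
compound 3 `CCn1cc2c(Oc3ccc(S(C)(=O)=O)cc3)cc(C(=O)Nc3cnc(C)cn3)cc2n1`: < 8 mL/min/kg

Each entry is a limit of the assay and not a number. Compound 3 stands at < 8 mL/min/kg in this assay and this too is only a limit. The whole measured set sits at the limit of < 8 mL/min/kg in this assay, at which 3 of the 3 values shown sit, and no order can be read within it.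

Compound 4 `CCCn1cc2c(Oc3ccc(S(C)(=O)=O)cc3)cc(C(=O)Nc3cnc(C)cn3)cc2n1` differs from compound 3 by ethyl to propyl, that is, methyl in place of hydrogen on a saturated chain carbon, two bonds along the chain from an aromatic nitrogen. The closest measured change is a step that the two limits leave unreadable from compound 1 to compound 3 on the same chain. The other change, a step that the two limits leave unreadable from compound 1 to compound 2 on the sulfonyl sulfur, is further removed. Neither gives a size to carry over, so no direction can be assigned.

The expectation is a step that the limit leaves unreadable from compound 3 to compound 4 with no shift beyond the scatter, and another reading at the limit is more likely than not. Compound 4 is estimated at 7 mL/min/kg within an expected range from 4 mL/min/kg to 13 mL/min/kg in clearance.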

Compound 4, clearance: < 8 mL/min/kg
Compound 4: a limit, no number; the forecaster's own chance of this, stated with the estimate: 65%; the middle value is on the limit's open side.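

In this assay compound 4 gives only a limit and not a number, so no new step can be read from compound 3 or compound 1 to compound 4. The compounds shown leave open any order in clearance among them, with all values at one limit: the limit of < 8 mL/min/kg in this assay, at which 4 of the 4 values shown sit.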